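Pyridin-4-yl in Place of Pyridin-3-yl on a Thioether Chain

A few compounds are considered here, and "the series" means these few. Any claim that something is new, unique, unknown or untested is made for them only; others in the source may bear on it.

Of the compounds shown here, three sharing one core have been tested in a functional assay on KB cells (Homo sapiens) for antiproliferative activity, read by sulforhodamine B assay, with a stated time of 72 h; on this read-out higher numbers stand for weaker inhibition of growth and lower numbers for stronger inhibition of growth. Compound 1 `Cc1cc(=O)oc2cc(Sc3cccc(Cl)n3)ccc12` gives 920 nM in this assay. Compound 2 `Cc1cc(=O)oc2cc(SCc3ccccn3)ccc12` reaches only the limit of the assay, reported as > 35200 nM, so no number is known for it. Compound 3 `Cc1cc(=O)oc2cc(SCc3cccnc3)ccc12` likewise sits at a limit, reported as > 35200 nM, which again is not a measured number. For the measured compounds named here, the one step between neighbouring measured compounds, a step that the two limits leave unreadable from compound 2 to compound 3, therefore cannot be read, because the limit of > 35200 nM in this assay, at which 2 of the 3 values shown sit, means both ends are capped at the same bound.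

Compound 4 `Cc1cc(=O)oc2cc(SCc3ccncc3)ccc12` differs from compound 3 by pyridin-4-yl in place of pyridin-3-yl on a saturated chain carbon bound to a sulfur. Going by the values given here, no measured step bears directly on this change, and the only neighbouring step is unreadable; what the numbers show is that the two compounds carrying a saturated chain carbon bound to a sulfur both lie at the limit, while compound 1, which lacks that chain carbon, gives a number. On that basis compound 4 is expected to behave like compound 3, most likely again at the limit, and the step from compound 3 to compound 4 is estimated as a step that the limit leaves unreadable from compound 3 to compound 4. The estimate for compound 4 in this assay is 40000 nM, with a range from 10000 nM to 150000 nM.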

Compound 4, concentration for 50% growth inhibition: > 35200 nM
Compound 4 gave a limit, no number (the forecaster's own chance of this, stated with the estimate: 75%); the middle value is on the limit's open side.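

Compound 4 also gives a limit rather than a number, so the steps among compound 2, compound 3 and compound 4 cannot be read, because all three are capped at the same bound: the limit of > 35200 nM in this assay, at which 3 of the 4 values shown sit.

The compounds shown leave open whether pyridin-2-yl, pyridin-3-yl and pyridin-4-yl on a saturated chain carbon bound to a sulfur differ at all in this assay.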